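Acetoxymethyl to hydroxymethyl: a small step expected

The source may report more compounds than this note shows. Statements on the series, on what has been measured and on what is new or still open speak of the compounds shown alone.

Measured in a functional assay on SMMC-7721 cells (Homo sapiens) for antiproliferative activity, read by MTT assay, with a stated time of 48 h; a lower number here means a stronger inhibitor, a higher number a weaker inhibitor:
- Compound 1 `CC(=O)OC/C1=C/C[C@](C)(CCC=C(C)C)/C=C/[C@@H](OC(=O)C=C(C)C)[C@](C)(O)/C=C/C1=O`: 2950 nM
- Compound 2 `CC(=O)OC/C1=C/C[C@](C)(CCC=C(C)C)/C=C/[C@@H](OC(=O)C=C(C)C)[C@](C)(OC(C)=O)/C=C/C1=O`: 4130 nM
- Compound 3 `COC/C1=C/C[C@](C)(CCC=C(C)C)/C=C/[C@@H](OC(=O)C=C(C)C)[C@](C)(OC)/C=C/C1=O`: 9380 nM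

Compound 2 lies within the scatter of compound 1, while the number for compound 3 is higher than that of compound 2 by more than the scatter. The next structure is compound 4 `CC(=O)O[C@]1(C)/C=C/C(=O)/C(CO)=C\C[C@](C)(CCC=C(C)C)/C=C/[C@H]1OC(=O)C=C(C)C`, which differs from compound 2 as follows: hydrogen in place of acetyl on an oxygen on a saturated carbon. This is acetoxymethyl to hydroxymethyl, with hydrogen in place of acetyl on an oxygen on a saturated carbon.

Going by the values given here, only one measured step bears on this: a 1.4-fold higher number from compound 1 to compound 2 (0.15 log units; within the scatter). It exchanges the same two groups, but in the opposite sense and at a different oxygen, so it is only an indirect guide. Among the compounds with values here, no measured pair tests the acetoxymethyl to hydroxymethyl change itself. With that single step inside the scatter, no step beyond the scatter is expected in this assay, and no direction is firmly indicated. The estimate corresponds to a 1.2-fold lower number from compound 2 to compound 4 (0.07 log units; within the scatter), which is expected to stay within the scatter. Compound 4 is estimated at 3500 nM, with an expected range of 1500 nM to 9000 nM.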

Compound 4, half-maximal inhibitory concentration: 3080 nM
The estimate for compound 4 lay 1.1-fold (0.06 log units) above the measured number; low and high end bracket the measured number.
By their numbers in this assay, from the lowest: compounds 1, 4 and 2 (each within the scatter of the next); then compound 3.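

In this assay, the acetoxymethyl to hydroxymethyl change now has a direct reading at this position: a 1.3-fold lower number from compound 2 to compound 4 (0.13 log units; within the scatter). Acetyl and hydrogen on this oxygen therefore cannot be told apart in this read-out, and the same holds at the other oxygen, where the step is a 1.4-fold higher number from compound 1 to compound 2 (0.15 log units; within the scatter). No measurement shown offers an explanation for this tolerance.

Still open, going by these compounds, is whether this position accepts anything beyond acetyl and hydrogen, such as a butyryl ester, a carboxylic acid or an amine in place of the hydroxymethyl. Compound 3 has methyl ethers on both oxygens, so it differs from the other compounds in more than one place and cannot show what a methyl ether does at this position alone.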